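From methyl to propyl on compound 2

A few compounds are considered here, and "the series" means these few. Any claim that something is new, unique, unknown or untested is made for them only; others in the source may bear on it.

Three related compounds have so far been measured in a functional assay on M21 cells (Homo sapiens) for antiproliferative activity, read by sulforhodamine B assay, with a stated time of 48 h (a lower number here means a stronger inhibitor, a higher number a weaker inhibitor), and give a first picture. Compound 2 (`CN1CCN(c2ccc(S(=O)(=O)Oc3c(Cl)cc(Cl)cc3Cl)cc2)C1=O`) reads 1700 nM and sits within the scatter of compound 3 (`CCN1CCN(c2ccc(S(=O)(=O)Oc3cccc(Br)c3)cc2)C1=O`) at 3400 nM while compound 1 (`CN1CCN(c2ccc(S(=O)(=O)Oc3cc(Cl)c(Cl)cc3Cl)cc2)C1=O`) at 420 nM is clearly lower, which means stronger. Compound 4 (`CCCN1CCN(c2ccc(S(=O)(=O)Oc3c(Cl)cc(Cl)cc3Cl)cc2)C1=O`) differs from compound 2 in one place (ethyl in place of hydrogen on a saturated chain carbon bound to an amide-type nitrogen in a ring) so the methyl becomes a propyl. For the measured compounds named here, no two measured compounds differ in only one place, so nothing shows this change directly. No step beyond the scatter is therefore expected, and the estimated change is a 1.2-fold higher number from compound 2 to compound 4 (0.07 log units; within the scatter) at most a rough guide. Compound 4 is expected at 2000 nM with 700 nM to 6000 nM as the estimated range.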

Compound 4, half-maximal inhibitory concentration: 56000 nM
The estimate for compound 4 lay 28-fold (1.45 log units) below the measured number; the whole stated range lies below it.
By their numbers in this assay, from the lowest: compound 1; then compounds 2 and 3 (each within the scatter of the next); then compound 4.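

Placing ethyl in place of hydrogen on a saturated chain carbon bound to an amide-type nitrogen in a ring, which turns methyl into propyl, gives a 33-fold higher number from compound 2 to compound 4 (1.52 log units; beyond the scatter) in this assay. This position is therefore far from indifferent to the length of the chain, and a small addition here can sharply weaken the compound. Nothing measured here explains the loss. On these data alone, it remains open whether a longer chain would weaken the compound further, and whether a propyl chain ending in an amine or a carboxylic acid would read the same on this core.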